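Sulfonyl substitution on a pyrazole-linked benzimidazole core

The compounds below may be only part of what the source reports. "The series", "measured", "known", "first", "only" and "open" are said of these compounds alone.

Among the measured compounds shown here, compound 1 `FC(F)(F)c1ccc(-c2nn(-c3ccccc3)cc2-c2nc3ccccc3[nH]2)cc1` is one of two compounds measured in a functional assay on HepG2 cells (Homo sapiens) for antiproliferative activity, read by MTT assay, with a stated time of 24 h (on this read-out higher numbers stand for weaker inhibition and lower numbers for stronger inhibition), and in this assay compound 1 gives 6030 nM, the highest of the two numbers. Compound 2 `Cc1ccc(-c2nn(-c3ccccc3)cc2-c2nc3ccccc3n2S(=O)(=O)c2ccc(Cl)cc2)cc1` gives 5520 nM in this assay, a value within the scatter of that of compound 1. Compound 3 `O=S(=O)(c1ccc(Br)cc1)n1c(-c2cn(-c3ccccc3)nc2-c2ccc(C(F)(F)F)cc2)nc2ccccc21` differs from compound 1 by (4-bromophenyl)sulfonyl in place of hydrogen on an aromatic nitrogen. With no measured step of this kind shown, and with compound 2 at 5520 nM sitting close to compound 1, the step of a 1.1-fold lower number from compound 1 to compound 3 (0.04 log units; within the scatter) is expected to stay within the scatter. Compound 3 is therefore estimated at 5500 nM in this assay, with a range from 2000 nM to 15000 nM.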

Compound 3, half-maximal inhibitory concentration: 2160 nM
Estimate against measurement, compound 3: 2.5-fold (0.41 log units) above, within the range that was stated.
By their numbers in this assay, from the lowest: compound 3; then compounds 2 and 1 (each within the scatter of the next).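

Among the compounds shown here, replacing hydrogen with (4-bromophenyl)sulfonyl on the aromatic nitrogen gives, in this assay, a 2.8-fold lower number from compound 1 to compound 3 (0.45 log units; beyond the scatter) and this is the first measured step at this position. It shows that this nitrogen can carry the sulfonyl group with stronger, not weaker, inhibition, although the step is modest. No evidence here accounts for the change. The compounds shown leave open whether the gain depends on the bromine or on the aromatic ring, and whether a smaller methylsulfonyl or an acetyl group on the same nitrogen would give a similar step.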